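The compounds below may be only part of what the source reports. "The series", "measured", "known", "first", "only" and "open" are said of these compounds alone.

Measured so far:
- compound 1, `Cc1ncc(-c2nc(Nc3ccc(C(=O)N4CCCN(C)CC4)cc3)ncc2F)n1C(C)C`, gives 2 in a physicochemical assay for lipophilicity; a higher number here means a more lipophilic compound, a lower number a more polar compound.
- compound 2, `Cc1ncc(-c2nc(Nc3ccc(C(=O)NCCN(C)C)c(F)c3)ncc2F)n1C(C)C`, gives 2.3 in this assay.

Of these two numbers, compound 1 has the lower one, but the gap to compound 2 lies within the usual scatter of repeated measurements, so the two compounds cannot be told apart on this basis.

Compound 3, `CN[C@H]1CCN(C(=O)c2ccc(Nc3ncc(F)c(-c4cnc(C)n4C(C)C)n3)cc2)C1`, has not yet been measured. It differs from compound 1 in one place: 3-(methylamino)pyrrolidin-1-yl in place of 4-methyl-1,4-diazepan-1-yl on a carbonyl carbon. The seven-membered ring with its two nitrogen atoms is replaced by a five-membered ring with one, and the new group brings one hydrogen-bond donor where the old one had none, with one heavy atom fewer overall.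

Going by the values given here, no measured pair shows this exact change, so there is no directly comparable step to lean on. A small downward step is expected in this assay, most likely within the scatter, since the change is modest in size and the rest of the molecule is unchanged. For compound 3 the estimated value is 1.8, with a range from 1.3 to 2.3. The expected step from compound 1 to compound 3 is a number 0.20 log units lower from compound 1 to compound 3 (within the scatter).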

Compound 3, distribution coefficient: 1.45
Beside the measured number, compound 3's estimate is 0.35 log units above it, within the range that was stated.
By their numbers in this assay, from the lowest: compound 3; then compounds 1 and 2 (each within the scatter of the next).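

Going by these compounds alone, this is the first pair of compounds that differ in one place, and it shows that the group on the carbonyl carbon can shift the reading in this assay by more than the scatter: 3-(methylamino)pyrrolidin-1-yl in place of 4-methyl-1,4-diazepan-1-yl gives a number 0.55 log units lower from compound 1 to compound 3 (beyond the scatter) with the rest of the molecule unchanged. The exchange is not a single simple edit, since a seven-membered ring with 2 hetero atoms gives way to a five-membered ring with 1 hetero atom, and the entering group brings 1 hydrogen-bond donor where the leaving group has 0. Nothing available here ties the step to any one of these differences.

The compounds shown leave open whether the step follows the ring or the hydrogen-bond donor, a question that 3-(dimethylamino)pyrrolidin-1-yl on the same carbonyl carbon could help to separate, as it keeps the five-membered ring and has no such donor. Going by these compounds, it is also open how 4-methylpiperazin-1-yl, or the other stereoisomer of 3-(methylamino)pyrrolidin-1-yl, would read at this place.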